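The compounds below may be only part of what the source reports. "The series", "measured", "known", "first", "only" and "open" are said of these compounds alone.

Working notes on the series.

Of the compounds shown here, three of the shared core have been measured in a functional assay on HepG2 cells (Homo sapiens) for inhibition, read by MTT assay, with a stated time of 72 h; a lower number here means a stronger inhibitor, a higher number a weaker inhibitor. Compound 1 `C#CCSc1nc(Nc2ccccc2)c2ccncc2n1` gives 29400 nM. Compound 2 `C#CCSc1nc(Nc2ccc(C)cc2)c2ccncc2n1` gives 6170 nM. Compound 3 `C#CCSc1nc(Nc2ccc(Cl)cc2)c2ccncc2n1` gives 36700 nM, the highest of the three numbers; compound 1 stands nearest, compound 2 furthest.

The steps among them: a 4.8-fold lower number from compound 1 to compound 2 (0.68 log units; beyond the scatter); a 1.2-fold higher number from compound 1 to compound 3 (0.10 log units; within the scatter); a 5.9-fold higher number from compound 2 to compound 3 (0.77 log units; beyond the scatter). So the one substituent change that moved the number beyond the scatter was the methyl, while the chloro left compound 3 close to compound 1.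

Compound 4 `C#CCSc1nc(Nc2ccc([N+](=O)[O-])cc2)c2ccncc2n1` differs from compound 3 by nitro in place of chloro on an aromatic carbon. Among the measured compounds shown here, no measured step involves a nitro group, so the bearing of the earlier steps is indirect: they show that a change at this position can move this assay by a modest amount in either direction, or not at all. With nothing to single out the nitro, the expected step in this assay from compound 3 is a 1.3-fold lower number from compound 3 to compound 4 (0.12 log units; within the scatter), essentially none beyond the scatter, with wide uncertainty on both sides.

For compound 4 the estimate in this assay is therefore 28000 nM, expected to fall between 8000 nM and 90000 nM.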

Compound 4, half-maximal inhibitory concentration: > 80000 nM
Compound 4 gave a limit, no number (the forecaster's own chance of this, stated with the estimate: 15%); middle value at least 2.8-fold (0.45 log units) from the limit.
By their numbers in this assay, from the lowest: compound 2; then compounds 1 and 3 (each within the scatter of the next). At a limit, above all of these: compound 4.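

In this assay compound 4 gives a limit and not a number: the limit of > 80000 nM in this assay, at which 1 of the 4 values shown sits.

Even as limits, all three new steps lie beyond the scatter: an at least 2.1-fold higher number from compound 3 to compound 4 (0.33 log units; beyond the scatter), an at least 2.7-fold higher number from compound 1 to compound 4 (0.43 log units; beyond the scatter) and an at least 12-fold higher number from compound 2 to compound 4 (1.11 log units; beyond the scatter). Among the compounds shown here, until now, the only change on this aromatic carbon to move the number beyond the scatter from the unsubstituted compound 1 was the methyl of compound 2, which lowered it, while the chloro of compound 3 stayed within the scatter; the nitro of compound 4 now shows that a substituent here can also raise the number beyond the scatter, so that the methyl and nitro compounds stand furthest apart among the four.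

Going by these compounds, what an amine or a carboxylic acid in the same place would do to the number remains open, as does how far past its limit compound 4 actually lies. The four compounds also leave open why the nitro and methyl groups differ so widely, and whether the same changes would have a similar effect elsewhere on this ring.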